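Ethyl to Methyl Tested on the Fluorophenyl Analogue

The source may hold more compounds than are shown below. What is called first, only, known or untested is meant among the compounds shown, and "the series" means these compounds.

In a functional assay on the whole organism (strain Swiss) with Mus musculus as the target, in the maximal electroshock model, with a stated time of 1 h, at a dose of 300 mg/kg by the intraperitoneal route (a lower number here means a weaker effect, a higher number a stronger effect of the compound at the dose given), compound 2, `CCC(C(=O)N1CCN(c2cccc(OC)c2)CC1)N1C(=O)CCC1=O`, gives 0%, and compound 1, `COc1cccc(N2CCN(C(=O)C(C)N3C(=O)CCC3=O)CC2)c1`, gives 0%. The change hydrogen in place of methyl on a saturated chain carbon, two bonds along the chain from an amide-type nitrogen in a ring and a carbonyl carbon made the step of no change at the digits printed from compound 2 to compound 1 (within the scatter). Compound 3, `CCC(C(=O)N1CCN(c2ccc(F)cc2)CC1)N1C(=O)CCC1=O`, differs from compound 2 in its core by 4-fluorophenyl in place of 3-methoxyphenyl on an amine nitrogen in a ring; in this assay compound 3 gives 25%, which is the step of a number 25 percentage points higher from compound 2 to compound 3 (beyond the scatter). Compound 4, `CC(C(=O)N1CCN(c2ccc(F)cc2)CC1)N1C(=O)CCC1=O`, has not been measured yet. It differs from compound 3 by hydrogen in place of methyl on a saturated chain carbon, two bonds along the chain from an amide-type nitrogen in a ring and a carbonyl carbon, the same change as between compound 2 and compound 1, at the same place. For compound 4 the estimated step of no change at the digits printed from compound 3 to compound 4 (within the scatter) is expected to stay within the scatter, because the same change gave no change at the digits printed from compound 2 to compound 1 (within the scatter) on the other core. Compound 4 is therefore expected to give about 25%, between 5% and 45%.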

Compound 4, a percentage reported as activity, at one dose (the size of the read-out at that dose, not a potency): 25%
Compound 4: the middle estimate sits on the measured number at the digits printed, within the range that was stated.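

In this assay the step for ethyl to methyl on the core of compound 3 reads no change at the digits printed from compound 3 to compound 4 (within the scatter) and matches the earlier step on the other core: the same change on two cores in this assay, no change at the digits printed (within the scatter) from compound 2 to compound 1 and no change at the digits printed (within the scatter) from compound 3 to compound 4, 0 percentage points apart, within the scatter of two such steps.
The 4-fluorophenyl in place of 3-methoxyphenyl change gives a number 25 percentage points higher from compound 1 to compound 4 (beyond the scatter) on the methyl side of the series and likewise carries over: the same change on two cores in this assay, a number 25 percentage points higher (beyond the scatter) from compound 2 to compound 3 and a number 25 percentage points higher (beyond the scatter) from compound 1 to compound 4, 0 percentage points apart, within the scatter of two such steps.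
This shows both changes behaving alike across these two pairs at one dose, but it does not show that either would carry over to a further core.

The compounds shown leave open whether a longer chain such as propyl on that saturated chain carbon would keep this reading. They also leave open what a chlorophenyl or an unsubstituted phenyl on the amine nitrogen in the ring would give.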